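Replacing the aryl oxygen substituent: compound 3 to compound 4

This account rests on a few compounds, and the source may have more. Where it says the series, first, only, none or still open, it means among the compounds named here.

Within the data shown here, compound 3 `CS(=O)(=O)Oc1ccccc1Cc1cnc(N)nc1N` gives 22900 nM in an assay for inhibition of Dihydrofolate reductase (Gallus gallus) (a higher number here means a weaker inhibitor, a lower number a stronger inhibitor), the second highest of the three numbers measured so far. Its nearest neighbour is compound 1 `CCCCOc1ccccc1Cc1cnc(N)nc1N`, which gives 8710 nM in this assay; the step of a 2.6-fold higher number from compound 1 to compound 3 (0.42 log units; beyond the scatter) separates them. Furthest away is compound 2 `Nc1ncc(Cc2ccccc2O)c(N)n1`, which gives 89100 nM, with a 3.9-fold lower number from compound 2 to compound 3 (0.59 log units; beyond the scatter) between the two. The ends of the measured range are joined by a 10-fold higher number from compound 1 to compound 2 (1.01 log units; beyond the scatter).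

Compound 4 `Nc1ncc(Cc2ccccc2I)c(N)n1` has not yet been measured. The change from compound 3 is: iodo in place of (methylsulfonyl)oxy on an aromatic carbon.

All three measured steps vary the group on the oxygen at this same place on the ring, while the change to compound 4 removes the oxygen altogether, so none of them matches it directly. The steps of a 2.6-fold higher number from compound 1 to compound 3 (0.42 log units; beyond the scatter) and a 3.9-fold lower number from compound 2 to compound 3 (0.59 log units; beyond the scatter) show that the group at this place moves the number in this assay by modest amounts in either direction. Compound 3 sits between compound 1 and compound 2, and a move toward compound 1 seems more likely than toward compound 2.

For compound 4 the expected step is a 2.5-fold lower number from compound 3 to compound 4 (0.41 log units; beyond the scatter), modest and downward, and it may fall within the scatter.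

Compound 4 is therefore estimated to give about 9000 nM in this assay, with a range from 3000 nM to 30000 nM.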

Compound 4, inhibition constant: 8710 nM
Beside the measured number, compound 4's estimate is 1.0-fold (0.01 log units) above it; the range from low to high includes it.
By their numbers in this assay, from the lowest: compounds 1 and 4 (each within the scatter of the next); then compound 3; then compound 2.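

Oxygen on this aromatic carbon is not needed for the lower numbers in this assay: with iodo in place of butoxy the result is no change at the digits printed from compound 1 to compound 4 (within the scatter), so a single heavy atom with no hydrogen-bond acceptor cannot be told apart from the butoxy group here. Swapping (methylsulfonyl)oxy for iodo gives a 2.6-fold lower number from compound 3 to compound 4 (0.42 log units; beyond the scatter) and swapping hydroxy for iodo gives a 10-fold lower number from compound 2 to compound 4 (1.01 log units; beyond the scatter), so the hydroxy compound remains the weakest of the four and the number does not simply follow the heavy-atom count of the group, since the five heavy atoms of (methylsulfonyl)oxy give a higher number than the one of iodo while the butoxy compound matches iodo. No measurement on hand accounts for why iodo and butoxy give matching numbers while hydroxy and (methylsulfonyl)oxy do not.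

Open, as far as these compounds go, is how bromo, chloro, an amine or an alkoxy chain longer than butoxy would read on this same aromatic carbon, and whether any of them would go beyond the level shared by compound 1 and compound 4. With only four groups at this one place, the match between iodo and butoxy may be a coincidence of two unrelated groups or the floor of a wider trend.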